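A few compounds are considered here, and "the series" means these few. Any claim that something is new, unique, unknown or untested is made for them only; others in the source may bear on it.

Working notes on the anilinoquinazoline-free description: the shared core carries a 4-(trifluoromethyl)benzylthio group and an arylamino substituent that varies across the set. Compound 1 `COc1ccccc1Nc1nc(SCc2ccc(C(F)(F)F)cc2)nc2ccccc12` carries a 2-methoxyphenyl on that nitrogen. In a functional assay on MDA-MB-231 cells (Homo sapiens) for cytotoxicity, read by MTT assay, with a stated time of 72 h (on this read-out higher numbers stand for weaker inhibition and lower numbers for stronger inhibition), compound 1 reports only a limit, > 50000 nM, not a number. Compound 2 `FC(F)(F)c1ccc(CSc2nc(Nc3cccc(Cl)c3)c3ccccc3n2)cc1` carries a 3-chlorophenyl and in this assay compound 2 gives 18000 nM. Compound 3 `O=[N+]([O-])c1ccc(Nc2nc(SCc3ccc(C(F)(F)F)cc3)nc3ccccc23)cc1` carries a 4-nitrophenyl and in this assay compound 3 gives 8670 nM. Among the two numbers in hand, compound 2 stands highest; the step of a 2.1-fold lower number from compound 2 to compound 3 (0.32 log units; beyond the scatter) is beyond the scatter, and the step of an at least 2.7-fold lower number from compound 1 to compound 2 (0.44 log units; beyond the scatter) is bounded only by the limit (the limit of > 50000 nM in this assay, at which 1 of the 3 values shown sits).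

The next compound, compound 4 `COc1ccc(Nc2nc(SCc3ccc(C(F)(F)F)cc3)nc3ccccc23)cc1OC`, differs from compound 2 in one place: 3,4-dimethoxyphenyl in place of 3-chlorophenyl on a nitrogen on an aromatic ring. The step that bears on it is an at least 2.7-fold lower number from compound 1 to compound 2 (0.44 log units; beyond the scatter), where a methoxy-bearing aryl sat at the limit and the chloro-bearing aryl gave a number. Returning to a methoxy-bearing aryl therefore points to a higher number for compound 4, possibly up to the limit again, so a rise beyond the scatter is expected in this assay: a 1.9-fold higher number from compound 2 to compound 4 (0.29 log units; within the scatter). The value of compound 4 is estimated at 35000 nM, with a range from 14000 nM to 80000 nM.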

Compound 4, half-maximal inhibitory concentration: 18900 nM
Estimate against measurement, compound 4: 1.9-fold (0.27 log units) above, and the stated range covers the measured number.
By their numbers in this assay, from the lowest: compound 3; then compounds 2 and 4 (each within the scatter of the next). At a limit, above all of these: compound 1.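

In this assay, the change from (3-chlorophenyl)amino to (3,4-dimethoxyphenyl)amino leaves the read-out flat (a 1.1-fold higher number from compound 2 to compound 4 (0.02 log units; within the scatter)), so a methoxy-bearing aryl on this nitrogen does not by itself go with a limit. Exchanging 4-nitrophenyl for 3,4-dimethoxyphenyl at the same place gives a modest separation (a 2.2-fold higher number from compound 3 to compound 4 (0.34 log units; beyond the scatter)), which leaves 4-nitrophenyl as the only aryl here with a number set apart from the other two numbers. The two methoxy-bearing aryls also part (an at least 2.6-fold lower number from compound 1 to compound 4 (0.42 log units; beyond the scatter)), with 3,4-dimethoxyphenyl giving a number and 2-methoxyphenyl not, but the size of this step rests on a limit and stays a bound: the limit of > 50000 nM in this assay, at which 1 of the 4 values shown sits.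

The compounds shown carry only substituted phenyl groups on this nitrogen, so the outcome with an unsubstituted phenyl, a benzyl group or a saturated amine such as morpholine remains open. The 4-(trifluoromethyl)benzylthio group is also constant throughout, leaving open what a carboxylic acid or a longer chain in its place would do to these numbers.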